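The source may report more compounds than this note shows. Statements on the series, on what has been measured and on what is new or still open speak of the compounds shown alone.

Of the compounds shown here, three built on one shared core have been tested in a functional assay for inhibition of transient receptor potential cation channel subfamily V member 1 (Homo sapiens), read by fluorescence and calcium flux (a lower number here means a stronger inhibitor, a higher number a weaker inhibitor), and they differ only in the group sitting on an oxygen on an aromatic ring. Compound 1 `COc1cc(-c2cc3c(O)nc(C)nc3cc2C(C)C)ccc1Cl` carries a methyl there and gives 14 nM. Compound 2 `CCOc1cc(-c2cc3c(O)nc(C)nc3cc2C(C)C)ccc1Cl` carries an ethyl there and gives 12 nM; the step of a 1.2-fold lower number from compound 1 to compound 2 (0.07 log units; within the scatter) shows the two as equivalent. Compound 3 `Cc1nc(O)c2cc(-c3ccc(Cl)c(OCC4CCC4)c3)c(C(C)C)cc2n1` carries a cyclobutylmethyl there and gives 144 nM, the highest number of the three, standing a 10-fold higher number from compound 1 to compound 3 (1.01 log units; beyond the scatter) and a 12-fold higher number from compound 2 to compound 3 (1.08 log units; beyond the scatter).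

Compound 4 `Cc1nc(O)c2cc(-c3ccc(Cl)c(OC(C)C)c3)c(C(C)C)cc2n1` has not yet been measured in this assay. Its difference from compound 3 is isopropyl in place of cyclobutylmethyl on an oxygen on an aromatic ring, so the group on that oxygen becomes smaller, closer in size to the methyl and ethyl of compounds 1 and 2. Going by the values given here, the steps that bear on this are the two large ones, from compound 1 and from compound 2 up to compound 3, which both show the number rising strongly when the group was enlarged to cyclobutylmethyl. Compound 4 undoes part of that enlargement, though no branched group has been measured here. Compound 4 is therefore expected to show a lower number, a step of a 4.8-fold lower number from compound 3 to compound 4 (0.68 log units; beyond the scatter), and its estimated value is 30 nM, within a range of 10 nM to 100 nM.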

Compound 4, half-maximal inhibitory concentration: 201 nM
Beside the measured number, compound 4's estimate is 6.7-fold (0.83 log units) below it, outside the stated range (above it).
By their numbers in this assay, from the lowest: compounds 2 and 1 (each within the scatter of the next); then compounds 3 and 4 (each within the scatter of the next).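

In this assay, replacing cyclobutylmethyl with isopropyl gives a 1.4-fold higher number from compound 3 to compound 4 (0.14 log units; within the scatter), so the two groups count as equivalent here, and a smaller group on this oxygen does not by itself bring the number back down. The sharper contrast lies with the small groups: one added methyl on the saturated chain carbon bound to the oxygen gives a 17-fold higher number from compound 2 to compound 4 (1.22 log units; beyond the scatter), while isopropyl in place of methyl gives a 14-fold higher number from compound 1 to compound 4 (1.16 log units; beyond the scatter). Among these four compounds, a branch on that carbon is therefore enough for a large rise but is not needed for one, since compound 3 has no branch on that carbon and still reads with compound 4.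

Nothing in the data shown gives a reason for this rise. Still open, as far as these compounds go, is where the rise sets in for other groups on this oxygen, such as a straight propyl chain or a cyclopropylmethyl, and whether a chain ending in a hydroxyl or an amine would read with the ethyl of compound 2 or with the isopropyl of compound 4.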